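A few compounds are considered here, and "the series" means these few. Any claim that something is new, unique, unknown or untested is made for them only; others in the source may bear on it.

Going by the values given here, compound 1 `C/C(C(=O)NC1CC1)=C(/C)c1cccc(C(F)(F)F)c1` gives 17.4 mg/kg in a functional assay on the whole organism with Mus musculus as the target (a lower number here means that less compound is needed, a higher number that more compound is needed for the effect), the lowest of the two numbers measured so far. Compound 2 `C#CCNC(=O)/C(C)=C(\C)c1cccc(C(F)(F)F)c1` gives 25.1 mg/kg in this assay, and the step of a 1.4-fold higher number from compound 1 to compound 2 (0.16 log units; within the scatter) lies within the scatter. Compound 3 `C/C(C(=O)NC1CC1)=C(\C)c1cccc(C(F)(F)F)c1` differs from compound 1 by the two compounds have the same atoms and bonds and differ only in configuration as drawn: 1 of 1 stereo elements differ; a double bond is drawn E in compound 1 and Z in compound 3. Among the compounds with values here, the one measured step, a 1.4-fold higher number from compound 1 to compound 2 (0.16 log units; within the scatter), changes the substituent on the amide nitrogen and leaves the double bond untouched, so no measured step bears on this change. In this assay compound 3 is expected at 25 mg/kg, in a range from 8 mg/kg to 80 mg/kg. The expected step is a 1.4-fold higher number from compound 1 to compound 3 (0.16 log units; within the scatter), with no firm direction.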

Compound 3, dose for half-maximal effect: 65.5 mg/kg
Compound 3: the middle estimate sits 2.6-fold (0.42 log units) below what was measured; measured number inside the range.
By their numbers in this assay, from the lowest: compounds 1 and 2 (each within the scatter of the next); then compound 3.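

In this assay the configuration of the double bond matters, with a 3.8-fold higher number from compound 1 to compound 3 (0.58 log units; beyond the scatter), a modest step and the only one shown that lies beyond the scatter. Going by these compounds alone, the change on the amide nitrogen, a 1.4-fold higher number from compound 1 to compound 2 (0.16 log units; within the scatter), showed no such separation, so this is the first sign that the series responds to a structural change. The step belongs to the double bond alone, because nothing else separates the pair: the fact that compounds 1 and 3 differ only in the configuration as drawn

As far as these compounds go, whether the same configuration change carries the same step with the propargyl group of compound 2 stays open. Also open, from the compounds shown here alone, is how a nitrile or a carboxylic acid in place of trifluoromethyl would read in either configuration.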